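Removing a methoxy group: effect on cytotoxicity readings

A few compounds are considered here, and "the series" means these few. Any claim that something is new, unique, unknown or untested is made for them only; others in the source may bear on it.

Measured so far:
compound 1 `COc1ccc(/C=C/C(=O)O)cc1OC(=O)c1nc(C)c(C)nc1C`: 160%
compound 2 `CCOC(=O)/C=C/c1cc(OC)c(OC(=O)c2nc(C)c(C)nc2C)c(OC)c1`: -13.6%
compound 3 `Cc1nc(C)c(C(=O)Oc2cccc(/C=C/C(=O)O)c2)nc1C`: 75.3%

All three were run in a functional assay on EA.hy 926 cells (Homo sapiens) for cytotoxicity, read by MTT assay, with stated times of 24 h and 12 h, tested at 50 uM; a higher number here means a stronger effect of the compound at the concentration tested, a lower number a weaker effect. Compound 1 and compound 3 differ in one place, (hydrogen in place of methoxy on an aromatic carbon), and the step from compound 1 to compound 3 is a number 84.7 percentage points lower from compound 1 to compound 3 (beyond the scatter). Compound 2 stands lowest of the three, beyond the scatter from both others. The difference between the core of compound 1 and the core of compound 2 is not broken down here.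

Compound 4 `CCOC(=O)/C=C/c1ccc(OC(=O)c2nc(C)c(C)nc2C)c(OC)c1` is not yet measured; it arises from compound 2 by hydrogen in place of methoxy on an aromatic carbon. This is the same kind of change as from compound 1 to compound 3, though not the same: there the site was para to a 2-carboxyethenyl group, here it is meta to a 2-(ethoxycarbonyl)ethenyl group and meta to a methoxy group. The earlier drop a number 84.7 percentage points lower from compound 1 to compound 3 (beyond the scatter) suggests a fall, yet compound 2 already sits near no effect at -13.6%. The step expected here is therefore small, a number 3.6 percentage points higher from compound 2 to compound 4 (within the scatter). For compound 4 the estimate is -10%, between -40% and 25%.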

Compound 4, a percentage reported as activity, at one concentration (the size of the read-out at that concentration, not a potency): 69.7%
Beside the measured number, compound 4's estimate is 79.7 percentage points below it; the measured number lies above the stated range.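

In this assay there is a number 83.3 percentage points higher from compound 2 to compound 4 (beyond the scatter) for this replacement of methoxy by hydrogen. The change therefore does not carry over from one core to the other with a fixed direction, and the earlier step gives no guide to the sign of this one: the same change on two cores in this assay, a number 84.7 percentage points lower (beyond the scatter) from compound 1 to compound 3 and a number 83.3 percentage points higher (beyond the scatter) from compound 2 to compound 4, 168 percentage points apart, beyond the scatter of two such steps. This does not show which feature of the cores sets the direction, as compound 1 and compound 2 differ in more than one place and the site of the change also differs.

Open, from the compounds shown here alone, is whether the carboxylic acid or the ethyl ester on the ethenyl chain goes with either direction. Also open, going by these compounds, is how an amide or an amine at that chain end would read on either core.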